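The source may hold more compounds than are shown below. What is called first, only, known or untested is meant among the compounds shown, and "the series" means these compounds.

Values so far in a functional assay on HT-29 cells (Homo sapiens) for inhibition, read by luminescence and CellTiter-Glo, with a stated time of 24 h; a higher number here means that more compound is needed for the effect, a lower number that less compound is needed

compound 1 `CN1C(=S)[C@@H](NC(=O)c2nc(Cc3ccccc3)n(C)n2)COc2ccccc21` gives 2.5 nM
compound 2 `CN1C(=S)[C@@H](NC(=O)c2nc(Cc3ccccc3)n(CCCC(F)(F)F)n2)COc2ccccc21` gives 2380 nM
compound 3 `CN1C(=S)[C@@H](NC(=O)c2nc(Cc3ccccc3)n(CCCC#N)n2)COc2ccccc21` gives 2400 nM

Compound 3 sits with compound 2 at the high end of these numbers, and the two cannot be told apart: a 1.0-fold higher number from compound 2 to compound 3 (0.00 log units; within the scatter) is all that separates them. Compound 1 lies far lower (see a 960-fold higher number from compound 1 to compound 3 (2.98 log units; beyond the scatter) for the gap).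

The next compound is compound 4 `CN1C(=S)[C@@H](NC(=O)c2nc(Cc3ccccc3)n(C3CCC3)n2)COc2ccccc21` with cyclobutyl in place of 3-cyanopropyl on an aromatic nitrogen. The measured steps that bear on this act at the same nitrogen. Both a 950-fold higher number from compound 1 to compound 2 (2.98 log units; beyond the scatter) and a 960-fold higher number from compound 1 to compound 3 (2.98 log units; beyond the scatter) are large, while the change of chain end in a 1.0-fold higher number from compound 2 to compound 3 (0.00 log units; within the scatter) stays within the scatter. No ring on that nitrogen has been measured, so the data fix no exact size for this step. A position between compound 1 and compound 3 is expected, nearer compound 3. In this assay the expected step is moderate and towards a lower number, estimated as a 6.0-fold lower number from compound 3 to compound 4 (0.78 log units; beyond the scatter) (with wide uncertainty). For compound 4 the estimated value is 400 nM (expected range 40 nM to 3000 nM).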

Compound 4, half-maximal effective concentration: 181 nM
Compound 4: the middle estimate sits 2.2-fold (0.34 log units) above what was measured; the measured number falls inside the stated range.
By their numbers in this assay, from the lowest: compound 1; then compound 4; then compounds 2 and 3 (each within the scatter of the next).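

In this assay, this aromatic nitrogen tolerates a group larger than methyl better than the two open chains suggested: cyclobutyl in place of 3-cyanopropyl gives (a 13-fold lower number from compound 3 to compound 4 (1.12 log units; beyond the scatter)), and in place of 4,4,4-trifluorobutyl it gives (a 13-fold lower number from compound 2 to compound 4 (1.12 log units; beyond the scatter)). Cyclobutyl still does not match methyl (a 72-fold higher number from compound 1 to compound 4 (1.86 log units; beyond the scatter)), so the position now shows three distinct levels, with the two chains together at the high end, cyclobutyl in the middle and methyl lowest. Nothing available explains why the ring and the chains differ at this nitrogen.

Going by these compounds, whether the ring itself or simply the shorter reach from the nitrogen sets this level remains open. Ethyl, isopropyl or cyclopropyl on the same nitrogen would help separate the two, and an unsubstituted butyl chain would show what the chain ends contribute.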